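A Formyl Group Enters the Core: An Expected Read-Out

The source may hold more compounds than are shown below. What is called first, only, known or untested is meant among the compounds shown, and "the series" means these compounds.

Compound 1 `Cc1ccc2c(Cc3nn4cc(-c5ccc(Cl)cc5)nc4s3)coc2c1`: 13.4%
Compound 2 `Cc1ccc2c(Cc3nn4cc(-c5ccc(Br)cc5)nc4s3)coc2c1`: 10.3%
Compound 3 `Cc1ccc2c(Cc3nn4cc(-c5ccc([N+](=O)[O-])cc5)nc4s3)coc2c1`: 13.4%

Three measured compounds share one core and differ only in the group carried by the phenyl ring. In a functional assay on the whole organism (strain Wistar albino) for inhibition, with Rattus norvegicus as the target, read by paw edema, with a stated time of 1 h, at a dose of 100 mg/kg by the oral route (on this read-out higher numbers stand for more inhibition at the one dose given (going by the name of the read-out) and lower numbers for less inhibition), compound 1 gives 13.4%, level with compound 3 at the digits shown. The step of a number 3.1 percentage points lower from compound 1 to compound 2 (within the scatter), the step of no change at the digits printed from compound 1 to compound 3 (within the scatter) and the step of a number 3.1 percentage points higher from compound 2 to compound 3 (within the scatter) all lie within the scatter, so the three read-outs cannot be told apart.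

Compound 4 `Cc1ccc2c(Cc3nn4c(C=O)c(-c5ccc(Cl)cc5)nc4s3)coc2c1` keeps the 4-chlorophenyl group of compound 1 and changes the shared core instead: formyl in place of hydrogen on an aromatic carbon. Going by the values given here, none of the measured steps touches this part of the molecule; each of them swaps one group on the phenyl ring and leaves the core alone. Among the compounds with values here, there is therefore no measured step that bears on the change from compound 1 to compound 4, and the only guide is the flat run of the three values, which suggests no step beyond the scatter.

Compound 4 is thus expected to give about 14% in this assay, with a range from 4% to 26%, which means an expected step of a number 0.6 percentage points higher from compound 1 to compound 4 (within the scatter).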

Compound 4, a percentage reported as inhibition, in the whole organism at one dose (the size of the read-out at that dose, not a potency): 11.4%
For compound 4 the middle estimate is 2.6 percentage points above the measured one, within the range that was stated.
By their numbers in this assay, from the lowest: compounds 2, 4, 1 and 3 (each within the scatter of the next).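

Placing a formyl group on this aromatic carbon, next to the ring atom that bears a 4-chlorophenyl group, gives in this assay a number 2 percentage points lower from compound 1 to compound 4 (within the scatter). The earlier compounds shown here spoke only of swaps on the phenyl ring, whereas this step shows that a change on the shared core, here hydrogen giving way to a group with a carbonyl, also leaves the read-out within the usual scatter, so all four compounds still cannot be told apart at this single dose. Nothing measured alongside these numbers bears on why this result came out as it did.

From the compounds shown here alone, whether a different group on this same carbon, such as an amine, a carboxylic acid or a longer chain, would move the read-out beyond the scatter remains open, since a single formyl group cannot speak for other groups at this position. Also open, going by these compounds, is whether formyl on the core would read the same with the bromo or nitro group of compound 2 and compound 3 on the phenyl ring in place of chloro.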